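The source may report more compounds than this note shows. Statements on the series, on what has been measured and on what is new or still open speak of the compounds shown alone.

Among the compounds with values here, compound 2 `O=C(O)CCc1ccc(NC(=O)C(C2CCCCC2)n2c(-c3ccc(Cl)cc3)nc3cc(F)c(F)cc32)cc1` gives the lowest of the two numbers measured so far in a functional assay for agonist activity at Bile acid receptor (Homo sapiens), read by a luciferase reporter (a higher number here means that more compound is needed for the effect, a lower number that less compound is needed), at 2000 nM. Within the data shown here, its nearest neighbour is compound 1 `O=C(O)c1cccc(NC(=O)C(C2CCCCC2)n2c(-c3ccc(Cl)cc3)nc3cc(F)c(F)cc32)c1`, which in this assay gives 10700 nM; the only measured step is a 5.4-fold lower number from compound 1 to compound 2 (0.73 log units; beyond the scatter), a modest change that arises from exchanging the acid-bearing group on the amide nitrogen.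

Compound 3 `O=C(O)c1ccc(NC(=O)C(C2CCCCC2)n2c(-c3ccc(Cl)cc3)nc3cc(F)c(F)cc32)nc1` is obtained from compound 2 by 5-carboxypyridin-2-yl in place of 4-(2-carboxyethyl)phenyl on an amide-type nitrogen. The step from compound 1 to compound 2 bears on this change only in part: it shows that reshaping the acid-bearing group moves the number by a modest but real amount, and compound 3, like compound 1, has no 2-carboxyethyl chain. Among the measured compounds shown here, no measured pair shows the effect of the ring nitrogen that enters with the 5-carboxypyridin-2-yl group. On this basis compound 3 is expected to give a higher number, with a step of a 2.5-fold higher number from compound 2 to compound 3 (0.40 log units; beyond the scatter). That expected step falls short of reversing the whole gain seen from compound 1 to compound 2. Compound 3 is therefore estimated at 5000 nM, within a range from 1500 nM to 16000 nM.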

Compound 3, half-maximal effective concentration: 10600 nM
Beside the measured number, compound 3's estimate is 2.1-fold (0.33 log units) below it, and the stated range covers the measured number.
By their numbers in this assay, from the lowest: compound 2; then compounds 3 and 1 (each within the scatter of the next).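

Exchanging 4-(2-carboxyethyl)phenyl for 5-carboxypyridin-2-yl on the amide-type nitrogen gives a 5.3-fold higher number from compound 2 to compound 3 (0.72 log units; beyond the scatter) in this assay and so removes the advantage that compound 2 holds over compound 1. The new group also brings a 1.0-fold lower number from compound 1 to compound 3 (0.00 log units; within the scatter) so the two groups that lack the 2-carboxyethyl chain cannot be told apart in this assay despite their different rings. Among the three compounds, only compound 2 carries that chain and only compound 2 stands apart, with neither of the others going against this, but no measurement at hand explains the pattern.

The step to compound 3 changes the chain and the ring nitrogen together, so the compounds shown leave open how much of it belongs to each, and compound 1 differs from compound 3 in both the ring nitrogen and the place of the carboxylic acid. Also open, from the compounds shown here alone, is whether a 4-carboxyphenyl group, a 6-(2-carboxyethyl)pyridin-3-yl group or a longer chain such as 3-carboxypropyl on the phenyl ring would keep or lower the number seen with compound 2.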